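The source may hold more compounds than are shown below. What is called first, only, known or untested is meant among the compounds shown, and "the series" means these compounds.

Compound 1 `C=C1[C@@H](OC(C)=O)C[C@@H]2[C@](C)(COC=O)[C@H](OC(C)=O)CC[C@@]2(C)[C@@H]1C[C@@H](Nc1ccc(O)cc1)C1=CCOC1=O` carries a 4-hydroxyphenyl on an amine nitrogen of the shared core, compound 2 `C=C1[C@@H](OC(C)=O)C[C@@H]2[C@](C)(COC=O)[C@H](OC(C)=O)CC[C@@]2(C)[C@@H]1C[C@@H](Nc1ccccc1)C1=CCOC1=O` carries a phenyl there, and compound 3 `C=C1[C@@H](OC(C)=O)C[C@@H]2[C@](C)(COC=O)[C@H](OC(C)=O)CC[C@@]2(C)[C@@H]1C[C@@H](Nc1ccc(OC)c(OC)c1)C1=CCOC1=O` carries a 3,4-dimethoxyphenyl. In a functional assay on KB cells (Homo sapiens) for cytotoxicity, read by sulforhodamine B assay (on this read-out lower numbers stand for stronger inhibition and higher numbers for weaker inhibition), compound 1 gives 28900 nM and compound 2 gives 32100 nM. The step between them is a 1.1-fold higher number from compound 1 to compound 2 (0.05 log units; within the scatter), so these two cannot be told apart.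

Compound 3 gives > 50000 nM, which is a limit of the assay and not a number. The steps to that limit are an at least 1.7-fold higher number from compound 1 to compound 3 (0.23 log units; that floor lies within the scatter) and an at least 1.5-fold higher number from compound 2 to compound 3 (0.19 log units; that floor lies within the scatter), and neither shows a firm gap.

Compound 4 `C=C1[C@@H](OC(C)=O)C[C@@H]2[C@](C)(COC=O)[C@H](OC(C)=O)CC[C@@]2(C)[C@@H]1C[C@@H](Nc1ccc(Br)cc1)C1=CCOC1=O` has 4-bromophenyl in place of 3,4-dimethoxyphenyl on an amine nitrogen. Among the compounds with values here, no measured compound carries bromine, so the estimate rests on the neighbours with a single substituent or none on the ring. Compound 1, at 28900 nM, and compound 2, at 32100 nM, suggest that compound 4 will probably land near them in this assay. That would mean a small expected move towards a lower number, estimated as an at least 1.7-fold lower number from compound 3 to compound 4 (0.25 log units; that floor lies within the scatter). Compound 4 could still reach the limit of the assay. For compound 4 the expected value is 28000 nM, with an estimated range of 12000 nM to 50000 nM.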

Compound 4, half-maximal inhibitory concentration: 24000 nM
Compound 4: middle estimate off by 1.2-fold (0.07 log units), on the high side, and the stated range covers the measured number.
By their numbers in this assay, from the lowest: compounds 4, 1 and 2 (each within the scatter of the next). At a limit, above all of these: compound 3.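

In this assay, within the data shown here, an at least 2.0-fold lower number from compound 3 to compound 4 (0.31 log units; beyond the scatter) is the first step at this amine nitrogen that clears the scatter, so the 3,4-dimethoxyphenyl can now be told apart from at least one other group there. Compound 3 sits at a limit and not at a number, so that step is only a floor: the limit of > 50000 nM in this assay, at which 1 of the 4 values shown sits. Bromo on the ring cannot be told apart from hydrogen or hydroxy, as a 1.3-fold lower number from compound 2 to compound 4 (0.13 log units; within the scatter) and a 1.2-fold lower number from compound 1 to compound 4 (0.08 log units; within the scatter) show, so the phenyl, 4-hydroxyphenyl and 4-bromophenyl compounds form one level group, and compound 3 separates clearly only from compound 4.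

As far as these compounds go, what stays open is whether both methoxy groups of compound 3 are needed for the loss, which a phenyl ring carrying a single methoxy group could help to settle. From the compounds shown here alone, it is also open whether anything on this nitrogen moves the number well away from this level group, such as a ring bearing an amine or a carboxylic acid, or a longer alkyl chain in place of the ring.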